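A few compounds are considered here, and "the series" means these few. Any claim that something is new, unique, unknown or untested is made for them only; others in the source may bear on it.

Measured so far in a functional assay on A549 cells (Homo sapiens) for antiproliferative activity, read by MTT assay, with a stated time of 48 h; on this read-out lower numbers stand for stronger inhibition and higher numbers for weaker inhibition
- compound 1 `O=c1cc(-c2ccccc2)oc2cc(O)c(OCCCCN3CCCC3)c(O)c12` gives 51000 nM
- compound 2 `COc1cc2oc(-c3ccccc3)cc(=O)c2c(O)c1OCCCN1CCN(C)CC1` gives 18000 nM

Compound 2 holds the lower of the two numbers, and its gap to compound 1 lies beyond the usual scatter. The two values alone do not show what accounts for that gap.

Compound 3 `COc1cc2oc(-c3ccccc3)cc(=O)c2c(O)c1OCCCCN1CCCC1` keeps the core of compound 2 and differs only in the side chain, as follows: (pyrrolidin-1-yl)methyl in place of 4-methylpiperazin-1-yl on a saturated chain carbon, three bonds along the chain from an oxygen on an aromatic ring. Read one bond further out, 3-(4-methylpiperazin-1-yl)propyl gives way to 4-(pyrrolidin-1-yl)butyl, the chain also carried by compound 1. Going by the values given here, no measured pair isolates this change, so the size of the step remains a judgement.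

A small move towards weaker inhibition, not beyond the scatter, is expected in this assay as a 1.4-fold higher number from compound 2 to compound 3 (0.14 log units; within the scatter). The expectation stays close to compound 2 at 18000 nM for the shared core and leans towards compound 1 at 51000 nM for the shared chain. For compound 3 the estimated value is 25000 nM, with an expected range of 9000 nM to 60000 nM.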

Compound 3, half-maximal inhibitory concentration: 13000 nM
For compound 3 the middle estimate is 1.9-fold (0.28 log units) above the measured one; measured number inside the range.
By their numbers in this assay, from the lowest: compounds 3 and 2 (each within the scatter of the next); then compound 1.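

In this assay, exchanging 3-(4-methylpiperazin-1-yl)propyl for 4-(pyrrolidin-1-yl)butyl gives a 1.4-fold lower number from compound 2 to compound 3 (0.14 log units; within the scatter), so this read-out does not separate the two side chains, even with the second nitrogen of the ring gone and the chain one carbon longer. Going by these compounds alone, with 4-(pyrrolidin-1-yl)butyl held constant, methyl in place of hydrogen on an oxygen on an aromatic ring gives a 3.9-fold lower number from compound 1 to compound 3 (0.59 log units; beyond the scatter), and of the two differences between compound 1 and compound 2, only this one has a step beyond the scatter. No accompanying measurement accounts for either step.

From the compounds shown here alone, in compound 3 the ring and the chain length change together, so the contribution of each remains open; a 3-(pyrrolidin-1-yl)propyl chain on the same core would separate them, and a morpholine ring on the propyl chain would extend the comparison to a different ring. Going by these compounds, whether the step seen with methyl extends to a larger group on that oxygen, such as ethyl, and whether it holds with 3-(4-methylpiperazin-1-yl)propyl as the side chain also remain open.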